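Phenyl for thiophen-3-yl on the alkyne of a thienopyridine ester

The compounds below may be only part of what the source reports. "The series", "measured", "known", "first", "only" and "open" are said of these compounds alone.

Compound 1 `COC(=O)c1sc2cc(C#Cc3cccnc3)cnc2c1N`: > 150000 nM
Compound 2 `COC(=O)c1sc2cc(C#Cc3ccsc3)cnc2c1N`: 27700 nM

In a functional assay on MCF7 cells (Homo sapiens) for inhibition, read by sulforhodamine B assay, with a stated time of 48 h (on this read-out lower numbers stand for stronger inhibition of growth and higher numbers for weaker inhibition of growth), compound 1 gives only a limit, > 150000 nM. Compound 2 gives the only number shown, 27700 nM. For the measured compounds named here, the step of an at least 5.4-fold lower number from compound 1 to compound 2 (0.73 log units; beyond the scatter) is the single measured step, and it concerns a different exchange; no measured step touches phenyl. Compound 3 `COC(=O)c1sc2cc(C#Cc3ccccc3)cnc2c1N` differs from compound 2 by phenyl in place of thiophen-3-yl on a triple-bonded carbon. Going by the values given here, with no step bearing on this change, a step within the scatter, a 1.1-fold lower number from compound 2 to compound 3 (0.04 log units; within the scatter), is expected. Compound 3 is therefore estimated at 25000 nM, between 8000 nM and 80000 nM.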

Compound 3, concentration for 50% growth inhibition: > 150000 nM
Compound 3: a limit, no number; the forecaster's own chance of this, stated with the estimate: 12%; middle value at least 6.0-fold (0.77 log units) away from the limit.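

In this assay, phenyl in place of thiophen-3-yl on a triple-bonded carbon gives an at least 5.4-fold higher number from compound 2 to compound 3 (0.73 log units; beyond the scatter), so at this place the five-membered sulfur ring of compound 2 cannot be swapped for a six-membered carbon ring without loss of growth inhibition. Compound 3 gives only a limit, > 150000 nM, so both six-membered rings shown now end at a limit. The step between compound 1 and compound 3 cannot be read, because both sit at the same limit: the limit of > 150000 nM in this assay, at which 2 of the 3 values shown sit.

On these data alone, it remains open whether furan-3-yl or thiophen-2-yl on the triple-bonded carbon would give a number. As far as these compounds go, it also remains open how an amine or a carboxylic acid on the thiophen-3-yl ring would shift the read-out.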